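Replacing the acid of compound 1 with an isopropyl amide chain

The source may report more compounds than this note shows. Statements on the series, on what has been measured and on what is new or still open speak of the compounds shown alone.

Compound 1 `O=C(O)c1ccc(NCc2cccc(Oc3ccccc3)c2)cc1` carries a carboxy group on the shared core. In a functional assay on CHO cells for agonist activity at Free fatty acid receptor 1 (Homo sapiens) (a higher number here means that more compound is needed for the effect, a lower number that less compound is needed), compound 1 gives only a limit of < 10000 nM, not a number. Compound 3 `O=C(O)[C@@H]1C[C@H]1c1ccc(NCc2cccc(Oc3ccccc3)c2)cc1`, which bears a 2-carboxycyclopropyl group in place of that carboxy group, gives 562 nM in this assay. The step that the limit leaves unreadable from compound 1 to compound 3 therefore cannot be read, as the record notes for (the limit of < 10000 nM in this assay, at which 1 of the 3 values shown sits). Compound 2 `Cc1nc(-c2ccc(C(F)(F)F)cc2)sc1CNc1ccc(OCC(=O)O)cc1`, built on a different core, gives 288 nM in this assay.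

Compound 4 `CC(C)NC(=O)CCc1ccc(NCc2cccc(Oc3ccccc3)c2)cc1` differs from compound 1 by 2-(isopropylcarbamoyl)ethyl in place of carboxy on an aromatic carbon. Among the measured compounds shown here, no measured step bears directly on this change: the only step that starts from compound 1 is a step that the limit leaves unreadable from compound 1 to compound 3, and it is unreadable. The three measured values all belong to compounds that keep a carboxy group somewhere, whereas compound 4 has none, so nothing here sets a size or direction for the step.

Without a readable step from compound 1, the estimate for compound 4 is taken to lie near the limit that compound 1 shows, at an expected 8000 nM with a range from 1500 nM to 40000 nM. The expected step is a step that the limit leaves unreadable from compound 1 to compound 4, and it is as likely that this assay returns only a limit for compound 4.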

Compound 4, half-maximal effective concentration: 39.8 nM
Beside the measured number, compound 4's estimate is 200-fold (2.30 log units) above it, outside the stated range (below it).
By their numbers in this assay, from the lowest: compound 4; then compounds 2 and 3 (each within the scatter of the next).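

Exchanging 2-carboxycyclopropyl for 2-(isopropylcarbamoyl)ethyl on an aromatic carbon, para to a large group, gives a 14-fold lower number from compound 3 to compound 4 (1.15 log units; beyond the scatter) in this assay. Among the compounds shown here, on the shared core, then, a low number at this position does not depend on a carboxy group, something the earlier compounds could not show, as each of them carries one. Steps that start at compound 1 still cannot be read, because its entry is a limit and not a number: the limit of < 10000 nM in this assay, at which 1 of the 4 values shown sits.

The compounds shown do not separate the parts of the new chain, so it stays open whether the step belongs to the amide, the isopropyl end or the ethyl link that holds them on the ring. Also open, as far as these compounds go, is how a carboxylic acid on the same ethyl link, or a smaller amide such as a methyl amide or a primary amide, would stand in this assay on the shared core, and whether the isopropyl amide chain would give a similar step on any other core.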